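Does Changing Shape Alone Shift Cytotoxicity?

The source may hold more compounds than are shown below. What is called first, only, known or untested is meant among the compounds shown, and "the series" means these compounds.

Of the compounds shown here, three have numbers so far in an ADME assay on Akata cells (Homo sapiens) for cytotoxicity; on this read-out lower numbers stand for higher toxicity in this test and higher numbers for lower toxicity in this test. Compound 1 `Nc1nc2c(ncn2/C=C2\C[C@@H]2[C@@H](O)CO)c(=O)[nH]1` gives 61000 nM, compound 2 `Nc1ncnc2c1ncn2/C=C1\C[C@@H]1[C@H](O)CO` gives 57000 nM, and compound 3 `Nc1ncnc2c1ncn2/C=C1\C[C@@H]1[C@@H](O)CO` gives 50600 nM. Compound 1 therefore stands level with the other two, as all three values lie within the scatter of one another.

The next compound, still unmeasured, is compound 4 `Nc1nc2c(ncn2/C=C2/C[C@@H]2[C@H](O)CO)c(=O)[nH]1`. Its difference from compound 1 is this: the two compounds have the same atoms and bonds and differ only in configuration as drawn: 2 of 3 stereo elements differ; a stereocentre at a saturated chain carbon is drawn R in compound 1 and S in compound 4; a double bond is drawn E in compound 1 and Z in compound 4. No atoms leave or enter. A stereocentre at a saturated chain carbon is drawn R in compound 1 and S in compound 4, and a double bond is drawn E in compound 1 and Z in compound 4.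

Among the compounds with values here, only one measured step bears on this change. The step of a 1.1-fold lower number from compound 2 to compound 3 (0.05 log units; within the scatter) involves a stereocentre alone, as the fact that compounds 2 and 3 differ only in the configuration as drawn shows, and it lies within the scatter. That step sits on a different core from compound 1, so it is only an indirect guide. Within the data shown here, no measured pair tests the double bond, so that half of the change remains open.

No shift beyond the scatter is expected in this assay, and the estimated change is a 1.1-fold lower number from compound 1 to compound 4 (0.02 log units; within the scatter). For compound 4 the expected value is 58000 nM, with an estimated range from 25000 nM to 120000 nM.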

Compound 4, half-maximal cytotoxic concentration: 54000 nM
The estimate for compound 4 lay 1.1-fold (0.03 log units) above the measured number; the measured number falls inside the stated range.
By their numbers in this assay, from the lowest: compounds 3, 4, 2 and 1 (each within the scatter of the next).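

In this assay the new result is a 1.1-fold lower number from compound 1 to compound 4 (0.05 log units; within the scatter), so two configuration changes made together on the core of compound 1 still leave the number within the scatter. The earlier step between compound 2 and compound 3 covered a stereocentre alone and on a different core, whereas this pair is the first to include the double bond going from E to Z, and it does so together with a stereocentre going from R to S. The comparison therefore concerns shape as drawn and nothing else, with no atoms leaving or entering: the fact that compounds 1 and 4 differ only in the configuration as drawn

The two changes arrive together, so this pair cannot show what the stereocentre or the double bond does alone on this core, or whether separate effects offset each other. As far as these compounds go, all four compounds carry the same hydroxyl groups on the side chain, so it remains open whether an amine or a carboxylic acid in place of a hydroxyl group would shift the number in this assay beyond the scatter.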